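This account rests on a few compounds, and the source may have more. Where it says the series, first, only, none or still open, it means among the compounds named here.

Compound 2 `CN(C)CCNc1nc(-c2ccc(NC(=O)Nc3ccccc3)cc2)nc2ccsc12` gives 640 nM in a functional assay on NCI-H460 cells (Homo sapiens) for cytotoxicity, read by MTT assay, with a stated time of 72 h; a lower number here means a stronger inhibitor, a higher number a weaker inhibitor; compound 1 `CN(C)CCCNc1nc(-c2ccc(NC(=O)Nc3ccccc3Cl)cc2)nc2c(Cl)c(Cl)sc12` gives 490 nM, and the two numbers lie within the scatter of each other, so nothing separates them. Compound 3 `CN(C)CCNc1nc(-c2ccc(NC(=O)Nc3ccc(Cl)cc3Cl)cc2)nc2ccsc12` differs from compound 2 by 2,4-dichlorophenyl in place of phenyl on an amide-type nitrogen. Within the data shown here, no measured pair isolates this change, and compound 1 carries a different core and chain, so it gives no direct guide. The step from compound 2 to compound 3 is expected to be small, a 1.4-fold lower number from compound 2 to compound 3 (0.15 log units; within the scatter), leaning toward a lower number but not clearly beyond the scatter. Compound 3 is estimated at 450 nM, within 180 nM to 1100 nM.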

Compound 3, half-maximal inhibitory concentration: 1650 nM
Compound 3: the middle estimate sits 3.7-fold (0.56 log units) below what was measured, outside the stated range (above it).
By their numbers in this assay, from the lowest: compounds 1 and 2 (each within the scatter of the next); then compound 3.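

At this amide-type nitrogen, replacing phenyl with 2,4-dichlorophenyl weakens the compound in this assay (a 2.6-fold higher number from compound 2 to compound 3 (0.41 log units; beyond the scatter)), a modest step beyond the scatter. Among these compounds, this is the first direct reading at this position, and it shows that the added chlorines do not leave the number unchanged on the core and chain of compound 2. No evidence bearing on the cause of this step is available.

Whether either chlorine alone accounts for the step remains open, since compound 1 differs in more than one place. Going by these compounds, how a methoxy or trifluoromethyl group on that phenyl would read also remains open.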